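Compound 4: 1H-Imidazol-1-yl in Place of 1H-1,2,4-Triazol-1-yl

The source may hold more compounds than are shown below. What is called first, only, known or untested is meant among the compounds shown, and "the series" means these compounds.

Of the compounds shown here, three sharing one core have so far been tested in a functional assay on NCI-H1975 cells (Homo sapiens) for inhibition, read by sulforhodamine B assay, tested at 10 uM; a higher number here means more inhibition at the concentration tested (going by the name of the read-out), a lower number less inhibition. Compound 2 `CN(C)c1ccc(C2CC(c3ccc(-n4cncn4)cc3)=NN2S(C)(=O)=O)cc1` gives -3.1%, the lowest of the three numbers. Compound 1 `CN(C)c1ccc(C2CC(c3ccc(-n4cncn4)cc3)=NN2C(=O)/C=C/c2ccccc2)cc1` gives -2.3%, so that a number 0.8 percentage points lower from compound 1 to compound 2 (within the scatter). Compound 3 `CN(C)c1ccc(C2CC(c3ccc(-n4cncn4)cc3)=NN2S(=O)(=O)c2ccc(OC(F)(F)F)cc2)cc1` gives 11.1%, so that a number 14.2 percentage points higher from compound 2 to compound 3 (beyond the scatter). Within these three, only the large 4-(trifluoromethoxy)phenyl on the sulfonyl sulfur moved the read-out beyond the scatter; compound 1 and compound 2 sit together near zero.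

Compound 4 `CN(C)c1ccc(C2CC(c3ccc(-n4ccnc4)cc3)=NN2S(C)(=O)=O)cc1` differs from compound 2 in one place: 1H-imidazol-1-yl in place of 1H-1,2,4-triazol-1-yl on an aromatic carbon. Among the measured compounds shown here, no measured step touches this five-membered aromatic ring: both the step from compound 1 to compound 2 and the step from compound 2 to compound 3 changed the group on the ring nitrogen and left the 1H-1,2,4-triazol-1-yl in place. Compound 4 keeps the methylsulfonyl of compound 2, the arrangement that gave the lowest number. For the measured compounds named here, with no step to guide the change and the methylsulfonyl, which gave the lowest number, retained, a step of a number 3.1 percentage points higher from compound 2 to compound 4 (within the scatter) is expected, that is, nothing beyond the scatter. Compound 4 is therefore estimated at 0%, with a range from -10% to 12%.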

Compound 4, a percentage reported as inhibition, at one concentration (the size of the read-out at that concentration, not a potency): -3.8%
For compound 4 the middle estimate is 3.8 percentage points above the measured one; the range from low to high includes it.
By their numbers in this assay, from the lowest: compounds 4, 2 and 1 (each within the scatter of the next); then compound 3.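

The step at the five-membered aromatic ring is the only measured one that touches this position, the aromatic carbon para to a large group, and in this assay it gives a number 0.7 percentage points lower from compound 2 to compound 4 (within the scatter). With the methylsulfonyl in place, 1H-imidazol-1-yl and 1H-1,2,4-triazol-1-yl therefore cannot be told apart in this read-out, although the entering ring has 2 hydrogen-bond acceptors rather than 3 and the same count of 5 heavy atoms. No measured property of these compounds bears on this result, so the step stands as an observation without an explanation.

This reading comes from a pair of compounds that both sit near zero, so the compounds shown leave open whether the same change would also make no difference with the 4-(trifluoromethoxy)phenyl on the sulfonyl sulfur of compound 3, the one arrangement here that moved the read-out beyond the scatter. Also open, on these data alone, is how a group of another kind on this aromatic carbon, such as an amine or a carboxylic acid, would read in place of the five-membered ring.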